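The source may report more compounds than this note shows. Statements on the series, on what has been measured and on what is new or still open speak of the compounds shown alone.

Measured so far in a functional assay on HepG2 cells (Homo sapiens) for inhibition, read by MTT assay, with a stated time of 48 h; a lower number here means a stronger inhibitor, a higher number a weaker inhibitor:

- compound 1 `COc1cc(/C=N/Nc2nc(-c3ccc(C(F)(F)F)cc3)cs2)c(Br)c(Br)c1OC` — compound 1 gives > 100000 nM, which is a limit of this assay.
- compound 2 `COc1cc(/C=N/Nc2nc(-c3ccccc3)cs2)c(Br)c(Br)c1OC` — compound 2 gives 33600 nM.
- compound 3 `COc1cc(/C=N/Nc2nc(-c3ccc(Br)cc3)cs2)c(Br)c(Br)c1OC` — compound 3 gives > 100000 nM, again a limit of this assay.

Two of the three values sit at the same limit, (the limit of > 100000 nM in this assay, at which 2 of the 3 values shown sit), so much of the series is read against a boundary rather than a number. From compound 3 to compound 2 the change is hydrogen in place of bromo on an aromatic carbon, and it gives an at least 2.9-fold lower number from compound 3 to compound 2 (0.47 log units; beyond the scatter). From compound 1 to compound 2 the change is hydrogen in place of trifluoromethyl on an aromatic carbon, and it gives an at least 2.9-fold lower number from compound 1 to compound 2 (0.47 log units; beyond the scatter). The cores of compound 1 and compound 3 differ by trifluoromethyl in place of bromo on an aromatic carbon, and between them the step is a step that the two limits leave unreadable from compound 1 to compound 3.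

Compound 4 `COc1cc(/C=N/Nc2nc(-c3ccc(C(F)(F)F)cc3)cs2)cc(Br)c1OC` is not yet measured in this assay. From compound 1 to compound 4 the change is hydrogen in place of bromo on an aromatic carbon. It is the same kind of change as from compound 3 to compound 2, but not the same: there the hydrogen entered para to a large group, here it enters ortho to a bromo group, ortho to a large group, meta to a methoxy group and para to a methoxy group.

The expectation for compound 4 is a step that the limit leaves unreadable from compound 1 to compound 4, resting on compound 1 sitting at the limit > 100000 nM and on the earlier step of an at least 2.9-fold lower number from compound 3 to compound 2 (0.47 log units; beyond the scatter) being read only against a limit. Compound 4 is therefore estimated at 120000 nM, with a range from 40000 nM to 400000 nM.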

Compound 4, half-maximal inhibitory concentration: 31200 nM
Compound 4: middle estimate off by 3.8-fold (0.59 log units), on the high side; measured number outside the range, below it.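

In this assay, hydrogen in place of bromo on an aromatic carbon gives an at least 3.2-fold lower number from compound 1 to compound 4 (0.50 log units; beyond the scatter), with the hydrogen entering ortho to a bromo group and para to a methoxy group. The direction of this change therefore carries over between two cores, even though the bromo leaves a different site in each, but the two sizes cannot be set against each other: the same change on two cores in this assay, an at least 2.9-fold lower number (0.47 log units; beyond the scatter) from compound 3 to compound 2 and an at least 3.2-fold lower number (0.50 log units; beyond the scatter) from compound 1 to compound 4; the limit leaves it open whether they differ. Neither step has a fixed size, and two cases do not make a rule for the series, since each step is read against a limit rather than a pair of numbers: the limit of > 100000 nM in this assay, at which 2 of the 4 values shown sit.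

The compounds shown leave open what happens when hydrogen stands at both places on the shared core, replacing the bromo that leaves compound 1 and also the trifluoromethyl, and whether the two changes then add up. Also open, as far as these compounds go, is what an amine or a carboxylic acid would give at the site the bromo leaves, and whether a longer chain in place of a methoxy group would change the value in this assay.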